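Aryl exchange on the chain: compound 2 to compound 3

The source may hold more compounds than are shown below. What is called first, only, known or untested is meant among the compounds shown, and "the series" means these compounds.

Of the compounds shown here, two have numbers so far. In a functional assay on MCF7 cells (Homo sapiens) for cytotoxicity (a lower number here means a stronger inhibitor, a higher number a weaker inhibitor), compound 1 `C=C/C=C\[C@H](C)[C@H](OC(N)=O)[C@@H](C)[C@H](O)[C@@H](C)C/C(C)=C\[C@H](C)[C@@H](O)[C@@H](C)/C=C\CCc1cccc(O)c1C` gives 490 nM and compound 2 `C=C/C=C\[C@H](C)[C@H](OC(N)=O)[C@@H](C)[C@H](O)[C@@H](C)C/C(C)=C\[C@H](C)[C@@H](O)[C@@H](C)/C=C\CCc1cc(F)cc(F)c1` gives 600 nM. Within the data shown here, the only measured step, a 1.2-fold higher number from compound 1 to compound 2 (0.09 log units; within the scatter), lies within the scatter, so compound 2 stands level with compound 1 on this read-out.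

Compound 3 `C=C/C=C\[C@H](C)[C@H](OC(N)=O)[C@@H](C)[C@H](O)[C@@H](C)C/C(C)=C\[C@H](C)[C@@H](O)[C@@H](C)/C=C\CCc1cccc(OC)c1` keeps the shared core and differs from compound 2 at one place: 3-methoxyphenyl in place of 3,5-difluorophenyl on a saturated chain carbon, two bonds along the chain from a double-bonded chain carbon. This puts 3-methoxyphenyl in place of 3,5-difluorophenyl on a saturated chain carbon, two bonds along the chain from a double-bonded chain carbon.

Among the measured compounds shown here, the one step that bears on this is the exchange of aryl groups at the same place, a 1.2-fold higher number from compound 1 to compound 2 (0.09 log units; within the scatter), and it stayed within the scatter. On that single pair, no step beyond the scatter is expected in this assay. For the measured compounds named here, no measured compound carries the 3-methoxyphenyl group, so the range is kept wide. The expected change is a 1.1-fold lower number from compound 2 to compound 3 (0.04 log units; within the scatter), an estimate only. For compound 3 the estimated value is 550 nM, with an expected range of 250 nM to 1200 nM.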

Compound 3, half-maximal inhibitory concentration: 330 nM
Compound 3: middle estimate off by 1.7-fold (0.22 log units), on the high side, and the stated range covers the measured number.
By their numbers in this assay, from the lowest: compounds 3, 1 and 2 (each within the scatter of the next).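

In this assay, the aryl place on the chain now holds three different groups on the shared core, and both a 1.8-fold lower number from compound 2 to compound 3 (0.26 log units; within the scatter) and a 1.5-fold lower number from compound 1 to compound 3 (0.17 log units; within the scatter) stay within the scatter, so compounds 1, 2 and 3 stand level on this read-out. The new information is that the exchange of 3,5-difluorophenyl, with two fluorine atoms and no hydrogen-bond acceptor, for 3-methoxyphenyl, with one oxygen atom and one hydrogen-bond acceptor, gives no step beyond the scatter at this place on a saturated chain carbon, two bonds along the chain from a double-bonded chain carbon. Nothing among the data available speaks to why these aryl groups stand level.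

All three compounds shown carry a substituted phenyl at this place, so it remains open whether an amine, a carboxylic acid, a pyridine ring or a longer chain there would give a step beyond the scatter. Also open, going by these compounds, is whether an unsubstituted phenyl would stand level with compounds 1, 2 and 3, and whether a group larger than those seen so far is accepted at this place.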